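This account rests on a few compounds, and the source may have more. Where it says the series, first, only, none or still open, it means among the compounds named here.

Measured so far in a functional assay on V79 cells (Cricetulus griseus) for cytotoxicity; a higher number here means a weaker inhibitor, a lower number a stronger inhibitor:
Compound 1 `CC(C)CCc1c(O)ccc2ccc(=O)oc12` gives 40000 nM.
Compound 2 `CC(C)CCc1cccc2ccc(=O)oc12` gives 60000 nM.

Among the measured compounds shown here, compound 2 stands at the higher of the two numbers, but its only neighbour, compound 1, sits close enough that the two cannot be told apart by this assay. Compound 3 `CCOc1ccc2ccc(=O)oc2c1CCC(C)C` is not yet measured; it differs from compound 2 by ethoxy in place of hydrogen on an aromatic carbon. For the measured compounds named here, the one measured step that touches this same aromatic carbon is a 1.5-fold higher number from compound 1 to compound 2 (0.18 log units; within the scatter), where a hydroxy was replaced by hydrogen without moving the number beyond the scatter. Going by the values given here, an ethoxy is a different group, and no measured pair shows one, so no step beyond the scatter is expected in this assay, with wide uncertainty. Compound 3 is therefore expected to give about 50000 nM, in a range from 15000 nM to 150000 nM. That estimate means an expected step of a 1.2-fold lower number from compound 2 to compound 3 (0.08 log units; within the scatter).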

Compound 3, half-maximal inhibitory concentration: 5800 nM
For compound 3 the middle estimate is 8.6-fold (0.94 log units) above the measured one, outside the stated range (below it).
By their numbers in this assay, from the lowest: compound 3; then compounds 1 and 2 (each within the scatter of the next).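

In this assay, this aromatic carbon, ortho to an isopentyl group, proves sensitive to what it carries: hydroxy and hydrogen there cannot be told apart, yet ethoxy gives a 10-fold lower number from compound 2 to compound 3 (1.01 log units; beyond the scatter). Putting ethyl on the oxygen of the hydroxy gives a similar result, with a 6.9-fold lower number from compound 1 to compound 3 (0.84 log units; beyond the scatter), so among these three compounds the lower number appears only when the oxygen carries the ethyl, not with the oxygen alone. Nothing available gives a cause for this shift.

The compounds shown leave open whether a methoxy, a longer chain on the same oxygen, or an amine on the same carbon would give a similar number. As far as these compounds go, all three also keep the isopentyl group, so how a shorter chain there would affect the ethoxy step remains unknown.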